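The source may report more compounds than this note shows. Statements on the series, on what has been measured and on what is new or still open speak of the compounds shown alone.

The three compounds here share one large core and differ only in the small aromatic ring at the far end of the molecule. Compound 1 `C=C1CC[C@@H]2[C@](C)(COC(C)=O)[C@H](OC(C)=O)CC[C@@]2(C)[C@H]1CC(Nc1ccc(S(=O)(=O)Nc2cc(C)on2)cc1)C1=CCOC1=O` was run in a functional assay on MCF7 cells (Homo sapiens) for inhibition, read by sulforhodamine B assay, with a stated time of 48 h (a higher number here means that more compound is tolerated, a lower number that less compound is tolerated), and gives "not determined" (no result reported). Compound 2 `C=C1CC[C@@H]2[C@](C)(COC(C)=O)[C@H](OC(C)=O)CC[C@@]2(C)[C@H]1CC(Nc1ccc(S(=O)(=O)Nc2nccc(C)n2)cc1)C1=CCOC1=O` carries a (4-methylpyrimidin-2-yl)sulfamoyl group. In this assay compound 2 gives > 100000 nM, which is a limit of the assay and not a measured number. So compound 2 stands at the limit of > 100000 nM in this assay, at which 1 of the 2 values shown sits, while the other entry has no number at all, and no step between two measured compounds can be drawn from these data.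

Compound 3 `C=C1CC[C@@H]2[C@](C)(COC(C)=O)[C@H](OC(C)=O)CC[C@@]2(C)[C@H]1CC(Nc1ccc(S(=O)(=O)Nc2ncccn2)cc1)C1=CCOC1=O` is the next compound to be measured. It differs from compound 2 by hydrogen in place of methyl on an aromatic carbon, turning the (4-methylpyrimidin-2-yl)sulfamoyl group into a (pyrimidin-2-yl)sulfamoyl group. Since compound 2 sits at a limit, only a loose expectation is possible: the step from compound 2 to compound 3 is estimated as a step that the limit leaves unreadable from compound 2 to compound 3, nothing beyond the scatter. Compound 3 is expected to give about 150000 nM in this assay, somewhere between 50000 nM and 500000 nM, most likely again only as a limit.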

Compound 3, concentration lethal to 50% of the cells: > 100000 nM
Compound 3: only a limit was reported; the forecaster's own chance of this, stated with the estimate: 80%; the middle value does not contradict the limit.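

In this assay compound 3 gives > 100000 nM, which is a limit of the assay and not a measured number. Compound 2 is also known only as a limit, so no step can be read between compound 2 and compound 3: the limit of > 100000 nM in this assay, at which 2 of the 3 values shown sit.

The compounds shown leave open whether swapping 4-methylpyrimidin-2-yl for pyrimidin-2-yl changes the result at all.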